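The source may hold more compounds than are shown below. What is called first, only, known or untested is meant among the compounds shown, and "the series" means these compounds.

Of the compounds shown here, three have so far been measured in a functional assay on SJ-G2 cells (Homo sapiens) for inhibition, read by MTT assay, with a stated time of 72 h; a lower number here means a stronger inhibitor of growth, a higher number a weaker inhibitor of growth. Within the data shown here, compound 1, with the structure `N#C/C(=C\c1c(F)c(F)c(F)c(F)c1F)C(=O)c1c[nH]c2ccccc12`, is the only one with a true number: in this assay compound 1 gives 14000 nM. Compound 3, with the structure `COc1ccc(CNC(=O)/C(C#N)=C/c2ccc(-c3ccccc3)o2)cc1`, reaches no number at all; in this assay compound 3 gives > 100000 nM, which is a limit of the assay. Compound 2, with the structure `N#C/C(=C\c1ccc[nH]1)C(=O)NCc1ccc(Cl)c(Cl)c1`, is the starting point of the step followed here. In this assay compound 2 gives > 50000 nM, again a limit and not a measured value. Compound 2 therefore has no exact place among the three: its value sits at the limit of > 50000 nM in this assay, at which 1 of the 3 values shown sits, one further value sits at the limit of > 100000 nM in this assay, at which 1 of the 3 values shown sits, and only compound 1 stands at a definite number.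

Compound 4, with the structure `N#C/C(=C\c1ccccc1)C(=O)NCc1ccc(Cl)c(Cl)c1`, differs from compound 2 in a single place: phenyl in place of 1H-pyrrol-2-yl on a double-bonded chain carbon bound to a double-bonded chain carbon. Among the measured compounds shown here, no step between two measured compounds is available for this change, so neither its size nor its direction can be read from the data. The step implied by the expectation, a number no higher from compound 2 to compound 4 (the limit leaves the size open), is expected to be nothing beyond the scatter. Compound 4 is expected to give about 50000 nM, within a range from 15000 nM to 150000 nM, and quite possibly again only a limit.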

Compound 4, concentration for 50% growth inhibition: 43000 nM
Compound 4: middle estimate off by 1.2-fold (0.07 log units), on the high side; measured number inside the range.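

In this assay, putting phenyl in place of 1H-pyrrol-2-yl on a double-bonded chain carbon bound to a double-bonded chain carbon gives an at least 1.1-fold lower number from compound 2 to compound 4 (0.06 log units; that floor lies within the scatter). The new information is that this place can carry a ring without the 1 hydrogen-bond donor of 1H-pyrrol-2-yl and still yield a true number, since compound 4 gives 43000 nM, and later changes here can be read against that value. Compound 2 remains a limit of the assay and not a number, so this step has only a floor and its real size stays unknown: the limit of > 50000 nM in this assay, at which 1 of the 4 values shown sits.

The compounds shown cannot tell whether the true difference between these two rings is negligible or large, and a firm value for the 1H-pyrrol-2-yl compound would be needed to settle that. They also leave open how the same place would respond to other groups, such as a pyridine ring, a phenyl ring bearing a carboxylic acid or an amine, or a longer chain, none of which appears among them.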